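The source may hold more compounds than are shown below. What is called first, only, known or untested is meant among the compounds shown, and "the series" means these compounds.

Three compounds sharing one core were examined in a functional assay on UO-31 cells (Homo sapiens) for inhibition, read by sulforhodamine B assay, tested at 10 uM; a higher number here means more inhibition at the concentration tested (going by the name of the read-out), a lower number less inhibition. Compound 1 `COc1cc2oc(-c3cccc(NC(=O)c4cccc(Br)c4)c3)cc(=O)c2c(OC)c1OC` is recorded in this assay as "active" (no number reported), and compound 2 `COc1cc2oc(-c3cccc(NC(=O)c4ccc(Br)cc4)c3)cc(=O)c2c(OC)c1OC` gives 63.6% in this assay. Compound 3 `COc1cc2oc(-c3cccc(NC(=O)c4cccc(C#N)c4)c3)cc(=O)c2c(OC)c1OC` is likewise recorded in this assay as "active" (no number reported), so no single number places it relative to the others; compound 1 is the one further entry without a figure, and compound 2 alone carries a number. Compound 4 `COc1cc2oc(-c3cccc(C(=O)Nc4ccc(Cl)cc4)c3)cc(=O)c2c(OC)c1OC` has not yet been measured in this assay. It differs from compound 3 by (4-chlorophenyl)carbamoyl in place of ((3-cyanophenyl)carbonyl)amino on an aromatic carbon. For the measured compounds named here, with no measured step of this kind to draw on, a modest shift in this assay in either direction is expected, quite possibly not beyond the scatter. For compound 4 an inhibition of 55% is estimated, with a range from 30% to 80%.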

Compound 4, a percentage reported as inhibition, at one concentration (the size of the read-out at that concentration, not a potency): 61.4%
Estimate against measurement, compound 4: 6.4 percentage points below, and the stated range covers the measured number.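

Exchanging ((4-bromophenyl)carbonyl)amino for (4-chlorophenyl)carbamoyl at this position gives, in this assay, a number 2.2 percentage points lower from compound 2 to compound 4 (within the scatter), so the two amide-linked aryl groups cannot be told apart here. The halogen and the direction of the amide change together in this step, so neither can be read alone, and the steps involving compound 1 and compound 3 cannot be read without numbers. No evidence is available to explain this result. From the compounds shown here alone, what remains open is how a carboxylic acid or an amine would read in place of the halogen, and whether a longer chain between the amide and the aromatic ring would shift the inhibition.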